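Amide side-chain change and cell tolerance in compound 3

The compounds below may be only part of what the source reports. "The series", "measured", "known", "first", "only" and "open" are said of these compounds alone.

Compound 2 `Cc1cc(C)cc(S(=O)(=O)c2c(C(=O)NC(c3ccc(Cl)cc3)C3CC3)[nH]c3ccc(Cl)cc23)c1` sits at the upper boundary of an ADME assay on MT4 cells (Homo sapiens) for cytotoxicity, read by MTT assay; a higher number here means that more compound is tolerated, a lower number that less compound is tolerated: its result in this assay, > 47300 nM, is a limit of the assay rather than a number, as the limit of > 47300 nM in this assay, at which 1 of the 2 values shown sits, records. Compound 1 `Cc1cc(C)cc(S(=O)(=O)c2c(C(=O)NC(C)C(=O)NC(C)c3ccncc3)[nH]c3ccc(Cl)cc23)c1`, which carries a different amide side chain on the shared core, gives 21900 nM in this assay.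

Compound 3 `Cc1cc(C)cc(S(=O)(=O)c2c(C(=O)NC(C)c3cc(F)cc(F)c3)[nH]c3ccc(Cl)cc23)c1` differs from compound 2 in one place: a group of 10 heavy atoms (8 carbon, 2 fluorine; one six-membered aromatic ring of carbon only) in place of a group of 11 heavy atoms (10 carbon, 1 chlorine; one three-membered non-aromatic ring of carbon only, one six-membered aromatic ring of carbon only), on an amide-type nitrogen

For the measured compounds named here, no measured step between two compounds of this set is available, so the size of this change can only be expected. For the step from compound 2 to compound 3 a small move downward is expected, an at least 1.2-fold lower number from compound 2 to compound 3 (0.09 log units; that floor lies within the scatter), not clearly beyond the scatter of this assay. Compound 3 is expected to give 38000 nM in this assay, with an estimated range from 15000 nM to 60000 nM.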

Compound 3, half-maximal cytotoxic concentration: > 49700 nM
Compound 3 was reported as a limit; the forecaster's own chance of this, stated with the estimate: 40%; middle value at least 1.3-fold (0.11 log units) from the limit.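

Compound 3 in this assay also gives a limit and not a number, so a second amide side chain now ends at the top of the read-out: the limit of > 49700 nM in this assay, at which 1 of the 3 values shown sits. The step between compound 2 and compound 3 cannot be read, since both values are limits, and the 1-(3,5-difluorophenyl)ethyl group cannot be ranked against the group it replaces on the amide-type nitrogen. For the compounds shown here, the one readable change is 3,5-difluorophenyl in place of (1-(pyridin-4-yl)ethyl)carbamoyl on a saturated chain carbon bound to an amide-type nitrogen and a saturated chain carbon, which gives an at least 2.2-fold higher number from compound 1 to compound 3 (0.35 log units; beyond the scatter).

On these data alone, how far compound 2 and compound 3 lie past their limits remains open. Also open, as far as these compounds go, is where the number in this assay would fall with an amine or a carboxylic acid on that saturated chain carbon.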